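Nitrophenyl for chlorophenyl on a semicarbazone side chain

The source may hold more compounds than are shown below. What is called first, only, known or untested is meant among the compounds shown, and "the series" means these compounds.

Of the compounds shown here, three have been measured in a functional assay on a cell-free system (plasma) for agonist activity at thromboxane A2 receptor (Homo sapiens); a higher number here means a weaker inhibitor, a lower number a stronger inhibitor. Compound 1 `O=C(O)CCC/C=C1\C[C@H]2C[C@@H](O)[C@H](/C=N/NC(=O)Nc3ccc([N+](=O)[O-])cc3)[C@H]2C1` gives 60 nM in this assay. Compound 2 `O=C(O)CCC/C=C1/C[C@H]2CC[C@H](/C=N/NC(=O)Nc3ccc([N+](=O)[O-])cc3)[C@H]2C1` gives 580 nM in this assay. Compound 3 `O=C(O)CCC/C=C1\C[C@H]2CC[C@H](/C=N/NC(=O)Nc3cccc(Cl)c3)[C@H]2C1` gives 6500 nM in this assay, the highest of the three numbers, beyond the scatter from both compound 2 and compound 1. Compound 4 `O=C(O)CCC/C=C1\C[C@H]2CC[C@H](/C=N/NC(=O)Nc3ccc([N+](=O)[O-])cc3)[C@H]2C1` has not yet been measured. It differs from compound 3 in one place: 4-nitrophenyl in place of 3-chlorophenyl on an amide-type nitrogen. Among the compounds with values here, both compound 1 and compound 2 carry the 4-nitrophenyl group and sit well below compound 3, whereas compound 3 is the only one with the 3-chlorophenyl group, so a downward step is expected. Compound 4 is expected to land near the numbers of compound 1 and compound 2, because compound 2 gives 580 nM and compound 1 gives 60 nM, giving an expected step of a 16-fold lower number from compound 3 to compound 4 (1.21 log units; beyond the scatter). The estimated value for compound 4 in this assay is 400 nM, in a range from 100 nM to 1500 nM.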

Compound 4, half-maximal inhibitory concentration: 1700 nM
Compound 4: middle estimate off by 4.3-fold (0.63 log units), on the low side; the whole stated range lies below it.
By their numbers in this assay, from the lowest: compound 1; then compound 2; then compound 4; then compound 3.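

In this assay, the aryl change alone gives a 3.8-fold lower number from compound 3 to compound 4 (0.58 log units; beyond the scatter), so 4-nitrophenyl in place of 3-chlorophenyl on the amide-type nitrogen counts for less than the earlier values suggested. The larger contribution lies elsewhere on the core, with hydrogen in place of hydroxy on the saturated ring carbon giving a 28-fold higher number from compound 1 to compound 4 (1.45 log units; beyond the scatter). The remaining step, a 2.9-fold higher number from compound 2 to compound 4 (0.47 log units; beyond the scatter), is also beyond the scatter, and the sole structural difference behind it is this: the fact that compounds 2 and 4 differ only in the configuration as drawn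

The compounds shown leave open whether the aryl step would keep its size with the hydroxy present or with the other double-bond geometry. They also leave open how a phenyl ring carrying an amino or methoxy group would compare on the same nitrogen.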